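The source may hold more compounds than are shown below. What is called first, only, known or untested is meant among the compounds shown, and "the series" means these compounds.

In a functional assay on HCT-8 cells (Homo sapiens) for antiproliferative activity, read by MTT assay, with a stated time of 48 h (a lower number here means a stronger inhibitor, a higher number a weaker inhibitor), compound 1 `CCNCC(=O)Nc1cc(OC)ccc1C(=O)c1ccc(OC)c2c1C=CC(C)(C)O2` stands at 7890 nM and compound 2 `C=C(c1ccc2c(c1)C=CC(C)(C)O2)c1ccc(OC)cc1NC(=O)CO` at 220 nM as the lower of the two numbers, with a gap beyond the scatter. Compound 3 `C=C(c1ccc2c(c1)C=CC(C)(C)O2)c1ccc(OC)cc1NC(=O)CN` differs from compound 2 by amino in place of hydroxy on a saturated chain carbon bound to a carbonyl carbon and so has amino in place of hydroxy on a saturated chain carbon bound to a carbonyl carbon. Among the measured compounds shown here, no measured pair shows this change. With compound 2 at 220 nM as the starting point, the expectation in this assay is no step beyond the scatter in either direction. The estimated 1.1-fold lower number from compound 2 to compound 3 (0.04 log units; within the scatter) stays within that expectation. For compound 3 the expected value is 200 nM within a range of 60 nM to 700 nM on this read-out.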

Compound 3, half-maximal inhibitory concentration: 220 nM
Compound 3: middle estimate off by 1.1-fold (0.04 log units), on the low side; low and high end bracket the measured number.
By their numbers in this assay, from the lowest: compounds 2 and 3 (each within the scatter of the next); then compound 1.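

Amino in place of hydroxy on a saturated chain carbon bound to a carbonyl carbon shows no change at the digits printed from compound 2 to compound 3 (within the scatter) in this assay and gives the first comparison in the series between compounds differing in one place. At this position on the shared core, this read-out does not separate the two groups. Nothing at hand offers an explanation for this result.

Still open, on these data alone, is how a dimethylamino group or a carboxylic acid at this position would read out. As far as these compounds go, a longer chain carrying the amino group also remains untested here.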